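Sulfanyl in place of hydrogen: clearance outlook for compound 3

A few compounds are considered here, and "the series" means these few. Any claim that something is new, unique, unknown or untested is made for them only; others in the source may bear on it.

In an ADME assay on S9 fraction from liver (Rattus norvegicus, strain Wistar) for metabolic stability, read by HPLC, using NADPH, tested at 20 uM (a lower number here means slower removal, a higher number faster removal of the compound), compound 1 `O=C(Nc1nc2ccccc2s1)c1ccc(OC(F)F)c(OCC2CC2)c1` gives 33.2 mL/min/kg and compound 2 `O=C(Nc1ccc2ncsc2c1)c1ccc(OC(F)F)c(OCC2CC2)c1` gives 22.3 mL/min/kg, two values within the scatter of each other. For the measured compounds named here, compound 2 is therefore not separated from the only other measured compound. Compound 3 `O=C(Nc1ccc2nc(S)sc2c1)c1ccc(OC(F)F)c(OCC2CC2)c1` differs from compound 2 in one place: sulfanyl in place of hydrogen on an aromatic carbon, next to the ring nitrogen and next to the ring sulfur. Going by the values given here, the only measured step, a 1.5-fold lower number from compound 1 to compound 2 (0.17 log units; within the scatter), puts 1,3-benzothiazol-6-yl in place of 1,3-benzothiazol-2-yl on an amide-type nitrogen and lies within the scatter. That step involves no sulfanyl, so the data offer no direction for this change, and no shift beyond the scatter is expected in this assay. The expected step is a 1.1-fold higher number from compound 2 to compound 3 (0.03 log units; within the scatter). The estimate for compound 3 is 24 mL/min/kg, with an expected range of 11 mL/min/kg to 50 mL/min/kg.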

Compound 3, clearance: 5.67 mL/min/kg
The estimate for compound 3 lay 4.2-fold (0.63 log units) above the measured number; the measured number lies below the stated range.
By their numbers in this assay, from the lowest: compound 3; then compounds 2 and 1 (each within the scatter of the next).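

In this assay, for the compounds shown here, the aromatic carbon next to the ring nitrogen and next to the ring sulfur is the first place where a single change moves the number beyond the scatter: sulfanyl in place of hydrogen gives a 3.9-fold lower number from compound 2 to compound 3 (0.59 log units; beyond the scatter). The earlier step, a 1.5-fold lower number from compound 1 to compound 2 (0.17 log units; within the scatter), moved the attachment point on the amide-type nitrogen and stayed within the scatter, so this substitution is the only change shown that separates two compounds. The data shown offer no measurement that bears on the reason for this step.

As far as these compounds go, it remains open whether the step belongs to sulfanyl itself or would also appear with another group on this carbon, such as methyl, an amine or a methoxy group. Also open, from the compounds shown here alone, is whether it would hold with methoxy in place of difluoromethoxy elsewhere on the shared core.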